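Two Methoxy Groups Added to a Hydroxamic Acid Benzamide

The compounds below may be only part of what the source reports. "The series", "measured", "known", "first", "only" and "open" are said of these compounds alone.

Of the compounds shown here, three sharing one core have been measured in a functional assay on SK-N-AS cells (Homo sapiens) for antiproliferative activity, with a stated time of 72 h; a lower number here means a stronger inhibitor, a higher number a weaker inhibitor. Compound 1 `COc1ccc(C(=O)N(CCC(=O)NCc2ccccc2)Cc2ccc(C(=O)NO)cc2)cc1` gives 1740 nM. Compound 2 `Cc1ccc(NC(=O)CCN(Cc2ccc(C(=O)NO)cc2)C(=O)c2ccc(N(C)C)cc2)cc1` gives 400 nM. Compound 3 `O=C(CCN(Cc1ccc(C(=O)NO)cc1)C(=O)c1ccccc1)NCc1ccccc1` gives 3310 nM, the highest of the three numbers; its nearest neighbour is compound 1, at a distance within the scatter, while the gap to compound 2 lies beyond the scatter.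

The step from compound 3 to compound 4 `COc1cc(OC)cc(C(=O)N(CCC(=O)NCc2ccccc2)Cc2ccc(C(=O)NO)cc2)c1` changes one place: 3,5-dimethoxyphenyl in place of phenyl on a carbonyl carbon. Among the compounds with values here, only one measured step bears on this change, namely a 1.9-fold higher number from compound 1 to compound 3 (0.28 log units; within the scatter), in which a methoxy group was replaced by hydrogen on an aromatic carbon without moving the number beyond the scatter. Compound 2 carries a different group on that ring and cannot be set beside compound 3 in a single step. Putting a methoxy group back, and adding a second one, would therefore be expected to shift the number little, if at all, so a step of a 1.4-fold lower number from compound 3 to compound 4 (0.16 log units; within the scatter) is expected. Compound 4 is thus estimated at 2300 nM, with a range from 1000 nM to 5500 nM.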

Compound 4, half-maximal inhibitory concentration: 9470 nM
Estimate against measurement, compound 4: 4.1-fold (0.61 log units) below; the whole stated range lies below it.
By their numbers in this assay, from the lowest: compound 2; then compounds 1 and 3 (each within the scatter of the next); then compound 4.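

In this assay, the position on the carbonyl carbon now shows a real response to its substituent, with a 2.9-fold higher number from compound 3 to compound 4 (0.46 log units; beyond the scatter) and a 5.4-fold higher number from compound 1 to compound 4 (0.74 log units; beyond the scatter). The earlier step between 4-methoxyphenyl and phenyl stayed within the scatter, which made methoxy groups on this ring look as if they hardly mattered, but the 3,5-dimethoxyphenyl group shows that this does not hold for every methoxy pattern: it moves the number in the weaker direction from both neighbours. No measurement available here explains why the number rises with this change.

The step from compound 1 to compound 4 changes both the number of methoxy groups and where they sit, so the compounds shown cannot separate the effect of adding a second methoxy group from the effect of its placement, and a 3-methoxyphenyl group on the same carbonyl carbon would help to tell these apart. Also open, as far as these compounds go, is how this position responds to groups other than methoxy when the rest of the molecule stays the same, such as a hydroxyl, a fluorine or an amine on the ring.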